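The compounds below may be only part of what the source reports. "The series", "measured", "known", "first", "only" and "open" are said of these compounds alone.

Measured compounds in an assay on isolated protein for inhibition of Fatty-acid amide hydrolase 1 (Homo sapiens), read by fluorescence; on this read-out higher numbers stand for weaker inhibition and lower numbers for stronger inhibition:
compound 1 `O=C(Oc1ccc([N+](=O)[O-])cc1)N1CCN(S(=O)(=O)c2ccc(C3CCCCC3)cc2)CC1` gives 333 nM
compound 2 `O=C(Oc1ccc([N+](=O)[O-])cc1)N1CCN(S(=O)(=O)c2ccc(-c3ccc(Cl)c(Cl)c3)cc2)CC1` gives 382 nM
compound 3 `O=C(Oc1ccc([N+](=O)[O-])cc1)N1CCN(S(=O)(=O)c2ccc(Oc3ccc(Cl)c(Cl)c3)cc2)CC1` gives 317 nM

Compound 3 has the lowest of the three numbers in this assay, but all three sit close together: a 1.1-fold lower number from compound 1 to compound 3 (0.02 log units; within the scatter), and a 1.2-fold lower number from compound 2 to compound 3 (0.08 log units; within the scatter). The remaining pair shows the same picture, a 1.1-fold higher number from compound 1 to compound 2 (0.06 log units; within the scatter). Exchanging cyclohexyl, 3,4-dichlorophenyl and 3,4-dichlorophenoxy at that aromatic carbon therefore moved nothing beyond the scatter.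

Compound 4 `O=C(Oc1ccc([N+](=O)[O-])cc1)N1CCN(S(=O)(=O)c2ccc(Oc3cccc(Cl)c3)cc2)CC1` differs from compound 3 by hydrogen in place of chloro on an aromatic carbon, on an aromatic carbon of a six-membered aromatic ring of carbon only, ortho to a chloro group and para to a large group; cut one bond further out this reads 3,4-dichlorophenoxy to 3-chlorophenoxy. Going by the values given here, no measured step removes a chloro from this outer ring, so nothing bears on it directly; the three measured steps only show that larger swaps of this whole distal group stayed within the scatter. On that basis a step within the scatter is expected for a 1.3-fold higher number from compound 3 to compound 4 (0.10 log units; within the scatter), with no direction asserted. Compound 4 is estimated at 400 nM, range 170 nM to 950 nM.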

Compound 4, half-maximal inhibitory concentration: 380 nM
Compound 4: middle estimate off by 1.1-fold (0.02 log units), on the high side, within the range that was stated.
By their numbers in this assay, from the lowest: compounds 3, 1, 4 and 2 (each within the scatter of the next).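

In this assay, the chloro group ortho to a chloro group and para to a large group can give way to hydrogen with no step beyond the scatter, at a 1.2-fold higher number from compound 3 to compound 4 (0.08 log units; within the scatter). Going by these compounds alone, this is the first single-chloro change in the outer ring, and the resulting 3-chlorophenoxy group also stays within the scatter of the other outer groups, at a 1.0-fold lower number from compound 2 to compound 4 (0.00 log units; within the scatter) and a 1.1-fold higher number from compound 1 to compound 4 (0.06 log units; within the scatter). Nothing further is available to bear on this result.

Going by these compounds, only chloro and hydrogen can be compared at this carbon, so how an amine, a carboxylic acid or a methoxy group there would read remains open. Also open, on these data alone, is whether losing the remaining chloro as well, giving a plain phenoxy group, would stay within the scatter.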